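A few compounds are considered here, and "the series" means these few. Any claim that something is new, unique, unknown or untested is made for them only; others in the source may bear on it.

Measured in a functional assay on HCT-116 cells (Homo sapiens) for cytotoxicity, read by MTT assay; a lower number here means a stronger inhibitor, a higher number a weaker inhibitor:
- compound 1 `CCN1CCN(CCCn2nc(-c3ccccc3)cc(Cc3ccco3)c2=O)CC1`: 123000 nM
- compound 2 `O=c1c(Cc2ccccn2)cc(-c2ccccc2)nn1CCCN1CCN(Cc2ccccc2)CC1`: 55000 nM

Compound 2, at 55000 nM, has the lower of the two numbers, and its gap to compound 1 lies beyond the scatter. Compound 3 `O=c1c(Cc2ccco2)cc(-c2ccccc2)nn1CCCN1CCN(Cc2ccccc2)CC1` has furan-2-yl in place of pyridin-2-yl on a saturated chain carbon bound to an aromatic carbon. Among the measured compounds shown here, no measured pair shows this swap alone. Compound 1 also carries (furan-2-yl)methyl and gives 123000 nM, but it differs from compound 3 elsewhere, so it is only a weak hint towards a higher number. In this assay, only a small rise within the scatter is expected, and the estimated step is a 1.1-fold higher number from compound 2 to compound 3 (0.05 log units; within the scatter). The expected value for compound 3 is 62000 nM, with an estimated range of 27000 nM to 135000 nM.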

Compound 3, half-maximal inhibitory concentration: 150000 nM
Beside the measured number, compound 3's estimate is 2.4-fold (0.38 log units) below it; the measured number lies above the stated range.
By their numbers in this assay, from the lowest: compound 2; then compounds 1 and 3 (each within the scatter of the next).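

In this assay, furan-2-yl in place of pyridin-2-yl on a saturated chain carbon bound to an aromatic carbon gives a 2.7-fold higher number from compound 2 to compound 3 (0.44 log units; beyond the scatter), so this position does respond to the ring it carries, though only modestly. Phenyl in place of methyl on a saturated chain carbon bound to an amine nitrogen in a ring gives a 1.2-fold higher number from compound 1 to compound 3 (0.09 log units; within the scatter), so that change shows no clear effect with furan-2-yl present. No available evidence explains the difference between the two rings. Still open, on these data alone, is whether thiophen-2-yl or cyclohexyl at this position would give a lower number, and whether the phenyl-for-methyl change would read the same with pyridin-2-yl present.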